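A few compounds are considered here, and "the series" means these few. Any claim that something is new, unique, unknown or untested is made for them only; others in the source may bear on it.

In a functional assay on UO-31 cells (Homo sapiens) for inhibition, read by sulforhodamine B assay, with a stated time of 48 h (a lower number here means a stronger inhibitor of growth, a higher number a weaker inhibitor of growth), three compounds have been measured: compound 1 `Nc1cc(N)c2nc(-c3ccccc3)c(NCc3ccc(Cl)c(Cl)c3)nc2c1` gives 4170 nM, compound 2 `COc1ccc(CNc2nc3cc(N)cc(N)c3nc2-c2ccccc2)cc1OC` gives 13500 nM, and compound 3 `Nc1cc(N)c2nc(-c3ccccc3)c(NCc3ccc(F)cc3)nc2c1` gives 3800 nM.

Compound 3 has the lowest number of the three, yet its gap to compound 1 is within the scatter, as a 1.1-fold lower number from compound 1 to compound 3 (0.04 log units; within the scatter) shows, while a 3.6-fold lower number from compound 2 to compound 3 (0.55 log units; beyond the scatter) is a modest step beyond it. Compound 4 `Nc1cc(N)c2nc(-c3ccccc3)c(Sc3ccc(Cl)c(Cl)c3)nc2c1` differs from compound 3 by (3,4-dichlorophenyl)sulfanyl in place of (4-fluorobenzyl)amino on an aromatic carbon. Of the measured steps, only a 1.1-fold lower number from compound 1 to compound 3 (0.04 log units; within the scatter) bears on this: exchanging the fluorophenyl for the dichlorophenyl made no difference beyond the scatter. Within the data shown here, no measured step changes the linking group itself, so that part is untested. The expected step is a 1.3-fold higher number from compound 3 to compound 4 (0.12 log units; within the scatter), with wide uncertainty. Compound 4 is estimated at 5000 nM, ranging from 1500 nM to 20000 nM.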

Compound 4, concentration for 50% growth inhibition: 3800 nM
The estimate for compound 4 lay 1.3-fold (0.12 log units) above the measured number, and the stated range covers the measured number.
By their numbers in this assay, from the lowest: compounds 3, 4 and 1 (each within the scatter of the next); then compound 2.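

In this assay, among these compounds, the first change to the link itself gives no change at the digits printed from compound 3 to compound 4 (within the scatter). The earlier compounds shown here changed only the aromatic ring on an unchanged benzylamino link, whereas here (3,4-dichlorophenyl)sulfanyl, with 0 hydrogen-bond donors, replaces (4-fluorobenzyl)amino, with 1, and the number stays within the scatter. Nothing measured here explains why the two numbers match.

As far as these compounds go, whether the sulfur link tolerates other aromatic rings, such as the 3,4-dimethoxyphenyl of compound 2, remains open. So does the outcome with an oxygen link or a morpholine at this aromatic carbon.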